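The compounds below may be only part of what the source reports. "The series", "measured", "known", "first", "only" and "open" are said of these compounds alone.

Working notes on the series, all read in a functional assay on Jurkat cells (Homo sapiens) for inhibition, read by CCK-8 assay, with a stated time of 48 h; a higher number here means a weaker inhibitor of growth, a lower number a stronger inhibitor of growth. Compound 1 `CN1CCN(c2ccc(Nc3ncc(Cl)c(NCc4ccc(F)cc4)n3)nc2)CC1` is reported only as a limit, > 100000 nM. Among the compounds with values here, compound 2 `CC(C)c1ccc(Nc2nc(Nc3ccc(N4CCN(C)CC4)cn3)ncc2Cl)cc1` gives 7530 nM, the only actual number so far. Within the data shown here, the one measured step is an at least 13-fold lower number from compound 1 to compound 2 (1.12 log units; beyond the scatter), with 4-isopropylphenyl in place of 4-fluorobenzyl on a nitrogen on an aromatic ring.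

Compound 3 `Cc1cc(C)c(Nc2nc(Nc3ccc(N4CCN(C)CC4)cn3)ncc2Cl)c(C)c1` changes the group at that same place: 2,4,6-trimethylphenyl in place of 4-isopropylphenyl on a nitrogen on an aromatic ring. Here 2,4,6-trimethylphenyl stands in place of 4-isopropylphenyl, with the same atoms joined differently. Among the measured compounds shown here, only the step to compound 2 bears on this change, and it compares a different pair of groups. It shows that the number can respond strongly to this group, but it does not fix a direction for the new change. With compound 2 at 7530 nM as the sole reference, a smaller move than that step is the working expectation, leaning towards weaker inhibition of growth. The expected step is a 2.0-fold higher number from compound 2 to compound 3 (0.30 log units; within the scatter), and its size remains uncertain. For compound 3 the estimated value is 15000 nM, with an expected range of 3000 nM to 70000 nM.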

Compound 3, concentration for 50% growth inhibition: 7600 nM
Estimate against measurement, compound 3: 2.0-fold (0.30 log units) above, within the range that was stated.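

In this assay, the change at this place, on a nitrogen on an aromatic ring, gives a 1.0-fold higher number from compound 2 to compound 3 (0.00 log units; within the scatter). Moving from 4-isopropylphenyl to 2,4,6-trimethylphenyl, with the same atoms joined differently, therefore leaves the read-out unchanged within the scatter, which the single earlier step could not show, and the large response seen before does not recur between these two groups. Compound 3 also gives a second case of a substituted phenyl on this nitrogen set against 4-fluorobenzyl, with an at least 13-fold lower number from compound 1 to compound 3 (1.11 log units; beyond the scatter), so compounds 2 and 3 agree on that side of the comparison, although that step has one open end, as the value of compound 1 is a limit and not a number: the limit of > 100000 nM in this assay, at which 1 of the 3 values shown sits.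

From the compounds shown here alone, it remains open whether the methyl or isopropyl groups matter at all, since plain phenyl, 4-fluorophenyl directly on the nitrogen, and a pyridine ring have no reading at this place here. The compounds shown also leave open how a carboxylic acid or a primary amine on this phenyl ring would read, and whether any group here can move the number well past that of compound 2.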